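The source may hold more compounds than are shown below. What is called first, only, known or untested is meant among the compounds shown, and "the series" means these compounds.

Working notes on a series in a functional assay on HCT-15 cells (Homo sapiens) for inhibition; on this read-out lower numbers stand for stronger inhibition and higher numbers for weaker inhibition: three compounds measured, one still to be run.

Compound 1 is `Oc1ccccc1-c1cc(-c2cccc(F)c2)cc(-c2ccccc2O)n1`. In this assay compound 1 gives > 50000 nM, which is a limit of the assay and not a number. Compound 2 is `Oc1ccccc1-c1cc(-c2ccc(F)cc2)cc(-c2ccccc2O)n1`. In this assay compound 2 gives > 50000 nM, again a limit. Compound 2 differs from compound 1 by 4-fluorophenyl in place of 3-fluorophenyl on an aromatic carbon, and the step is a step that the two limits leave unreadable from compound 1 to compound 2.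

Compound 3 is `Oc1ccc(-c2cc(-c3cccc(F)c3)cc(-c3ccc(O)cc3)n2)cc1`. In this assay compound 3 gives > 50000 nM, also a limit. The difference between the core of compound 1 and the core of compound 3 is not broken down here.

Compound 4 is `Oc1ccc(-c2cc(-c3ccc(F)cc3)cc(-c3ccc(O)cc3)n2)cc1` and awaits measurement. It differs from compound 3 by 4-fluorophenyl in place of 3-fluorophenyl on an aromatic carbon, the same kind of change as that from compound 1 to compound 2, the place now lying meta to two 4-hydroxyphenyl groups instead of meta to two 2-hydroxyphenyl groups. Among the measured compounds shown here, every measured value so far sits at the limit of > 50000 nM in this assay, at which 3 of the 3 values shown sit.

The step from compound 3 to compound 4 is expected to be a step that the limit leaves unreadable from compound 3 to compound 4, resting on compound 1 and compound 2 both sitting at the limit of > 50000 nM in this assay, at which 3 of the 3 values shown sit. Compound 4 is thus expected to give 60000 nM, estimated to fall between 20000 nM and 200000 nM.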

Compound 4, half-maximal inhibitory concentration: 4970 nM
The estimate for compound 4 lay 12-fold (1.08 log units) above the measured number; measured number outside the range, below it.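

In this assay, going by these compounds, 4-fluorophenyl in place of 3-fluorophenyl, on the core carrying two 4-hydroxyphenyl groups, gives an at least 10-fold lower number from compound 3 to compound 4 (1.00 log units; beyond the scatter); the true size of this step stays open, since the value of compound 3 is a limit. The same change on the core of compound 1 cannot be read, because the values at both of its ends are limits: the limit of > 50000 nM in this assay, at which 3 of the 4 values shown sit. The change is thus shown to give a readable number on one core only, which neither shows that its effect carries from one core to the other nor shows that it fails to carry.

What the compounds shown leave open is what lies behind the step, since only this one pair with a readable step is available. Also open, on these data alone, is how an amine or a carboxylic acid in place of the fluorine of the 4-fluorophenyl group of compound 4 would read in this assay.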